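The compounds below may be only part of what the source reports. "The series", "measured", "known", "first", "only" and "open" are said of these compounds alone.

Compound 1 `CCCCc1ccc(-c2c(C)[nH]c(=O)n2CCCC)cc1` gives 12000 nM
Compound 2 `CCCCc1ccc(-c2c(C)[nH]c(=O)n2C2CCCCC2)cc1` gives 27100 nM
Compound 3 `CCCc1ccc(-c2c(C)[nH]c(=O)n2C)cc1` gives 21500 nM

In a functional assay on brain (Rattus norvegicus, strain Wistar) for inhibition (a lower number here means a stronger inhibitor, a higher number a weaker inhibitor), compound 3 gives 21500 nM, a value within the usual scatter of those of both compound 1 and compound 2. Only compound 1 and compound 2 lie apart by more than the scatter.

Compound 4 `Cc1[nH]c(=O)n(C)c1-c1ccc(OCCC(C)C)cc1` has isopentyloxy in place of propyl on an aromatic carbon. Within the data shown here, no measured compound carries an oxygen-linked chain at that place, so no measurement tests this change directly.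

Among the measured compounds shown here, the only measured step is a 2.3-fold higher number from compound 1 to compound 2 (0.35 log units; beyond the scatter). It is modest, and it concerns a group on an aromatic nitrogen rather than the aromatic carbon that changes here. Compound 1 has butyl on that aromatic carbon and also differs from compound 3 on the nitrogen. Even so, compound 1 at 12000 nM stays within the scatter of compound 3. Across these compounds, then, changing the groups has moved the numbers only modestly, and a large step would be a surprise.

The expected change is small, leaning slightly towards a lower number, and is unlikely to clear the scatter: a 1.4-fold lower number from compound 3 to compound 4 (0.16 log units; within the scatter). For compound 4 the estimated value is 15000 nM, with an expected range from 6000 nM to 40000 nM.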

Compound 4, half-maximal inhibitory concentration: 6600 nM
Beside the measured number, compound 4's estimate is 2.3-fold (0.36 log units) above it; the measured number falls inside the stated range.
By their numbers in this assay, from the lowest: compounds 4, 1, 3 and 2 (each within the scatter of the next, the first and the last beyond it).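

In this assay, putting isopentyloxy in place of propyl on an aromatic carbon of the six-membered ring gives a 3.3-fold lower number from compound 3 to compound 4 (0.51 log units; beyond the scatter), so a stronger inhibitor results. Among these compounds, this is the first change at this aromatic carbon to be read on its own, and it shows that the group here can move the number by more than the scatter, even though the step is modest. Among the compounds shown here, until now, the only step that cleared the scatter was at a different place, a group on an aromatic nitrogen, and nothing measured bears on why this swap lowers the number.

For the compounds shown here, the single step changes several things at once: the group goes from the 3 heavy atoms of propyl to the 6 of isopentyloxy, and it gains an oxygen as the link to the ring. The compounds shown therefore leave open whether the oxygen or the length and branching of the chain matters, a question that a hexyl chain with no oxygen, a short methoxy group or an unbranched pentyloxy chain at this place could help to separate.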